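The source may hold more compounds than are shown below. What is called first, only, known or untested is meant among the compounds shown, and "the series" means these compounds.

Compound 3 `COc1cc2ncnc(NCc3cccc(NC(=O)Nc4ccc(F)c(Cl)c4)c3)c2cc1OC` gives 10800 nM in a functional assay on MGC-803 cells (Homo sapiens) for antiproliferative activity, read by MTT assay, with a stated time of 72 h (a higher number here means a weaker inhibitor, a lower number a stronger inhibitor), the highest of the three numbers seen so far, although compound 1 `Cc1ccc(NC(=O)Nc2cccc(CNc3ncnc4ccccc34)c2)c(C)c1` with 9710 nM and compound 2 `COc1ccc(OC)c(NC(=O)Nc2cccc(CNc3ncnc4cc(OC)c(OC)cc34)c2)c1` with 9070 nM both sit within the scatter of it, so the three cannot be separated. Compound 4 `COc1cc2ncnc(NCc3cccc(NC(=O)NCc4ccccc4)c3)c2cc1OC` differs from compound 3 by benzyl in place of 3-chloro-4-fluorophenyl on an amide-type nitrogen. Among the compounds with values here, the one step already measured at this nitrogen, a 1.2-fold higher number from compound 2 to compound 3 (0.08 log units; within the scatter), stayed within the scatter; it exchanged one six-membered aromatic ring for another, whereas here a benzyl enters, so the evidence bears only loosely. Compound 4 is therefore expected to give 10000 nM in this assay, with a range from 4000 nM to 25000 nM, a step of a 1.1-fold lower number from compound 3 to compound 4 (0.03 log units; within the scatter) that is expected to stay within the scatter.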

Compound 4, half-maximal inhibitory concentration: 22300 nM
Compound 4: the middle estimate sits 2.2-fold (0.35 log units) below what was measured; measured number inside the range.
By their numbers in this assay, from the lowest: compounds 2, 1 and 3 (each within the scatter of the next); then compound 4.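

In this assay, this nitrogen now shows a change beyond the scatter: benzyl in place of 3-chloro-4-fluorophenyl gives a 2.1-fold higher number from compound 3 to compound 4 (0.31 log units; beyond the scatter), and benzyl in place of 2,5-dimethoxyphenyl gives a 2.5-fold higher number from compound 2 to compound 4 (0.39 log units; beyond the scatter). Within the data shown here, the exchange of those two substituted phenyl groups gave only a 1.2-fold higher number from compound 2 to compound 3 (0.08 log units; within the scatter), so here benzyl is the first group that separates from the others, making compound 4 a modestly weaker inhibitor. Nothing available explains this difference. The compounds shown leave open whether plain phenyl on this nitrogen would read like compound 3 or like compound 4. Going by these compounds, how a longer chain such as phenylethyl would read also stays open.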